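A few compounds are considered here, and "the series" means these few. Any claim that something is new, unique, unknown or untested is made for them only; others in the source may bear on it.

Series note. The shared core carries a cyclohexylurea sulfonamide on a piperidine and an amide at the far end; the variation sits on the carbonyl carbon of that amide. In a functional assay on the whole organism (blood) with Rattus norvegicus as the target, with stated times of 24 h and 1 h, at a dose of 5 mg/kg by the intraperitoneal route (a higher number here means a stronger effect of the compound at the dose given, a lower number a weaker effect), compound 1 `COc1ncccc1C(=O)NCCC1CCN(S(=O)(=O)NC(=O)NC2CCCCC2)CC1` gives 33%, while compound 2 `COc1ccc2nccc(C(=O)NCCC3CCN(S(=O)(=O)NC(=O)NC4CCCCC4)CC3)c2c1` gives 15%, the lower of the two numbers shown; the step of a number 18 percentage points lower from compound 1 to compound 2 (beyond the scatter) is the only measured one and is modest. Compound 3 `O=C(NC1CCCCC1)NS(=O)(=O)N1CCC(CCNC(=O)c2cc(Cl)cc3cccnc23)CC1` is not yet measured; it differs from compound 2 by 6-chloroquinolin-8-yl in place of 6-methoxyquinolin-4-yl on a carbonyl carbon. That measured step swaps one aryl group for another on the same carbonyl carbon, so it bears on the present change only in kind, and its modest size gives no clear direction for a second aryl swap. The expectation for compound 3 is therefore a step of a number 5 percentage points higher from compound 2 to compound 3 (within the scatter) that stays within the scatter, with compound 3 estimated at 20%, between 5% and 40%.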

Compound 3, a percentage reported as activity, at one dose (the size of the read-out at that dose, not a potency): 52%
The estimate for compound 3 lay 32 percentage points below the measured number, and the stated range ends below it.
By their numbers in this assay, from the lowest: compound 2; then compound 1; then compound 3.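

Swapping in 6-chloroquinolin-8-yl on the carbonyl carbon gives a number 37 percentage points higher from compound 2 to compound 3 (beyond the scatter), and against the earlier 2-methoxypyridin-3-yl it gives a number 19 percentage points higher from compound 1 to compound 3 (beyond the scatter), so in this assay compound 3 stands highest of the three and this position can raise the read-out as well as lower it. The two quinolinyl groups have the same count of aromatic rings, so that count alone does not set the read-out at this position. No measurement at hand accounts for these differences.

The step changes the chlorine for the methoxy group and the point of attachment together, so 6-methoxyquinolin-8-yl and 6-chloroquinolin-4-yl would be needed to tell the two apart. Also open, on these data alone, is how a nitrile or an amine on the quinoline would read, and whether the order of the three compounds holds at other doses.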